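Benzoyl for phenyl on a triazole thioether: limits only

The compounds below may be only part of what the source reports. "The series", "measured", "known", "first", "only" and "open" are said of these compounds alone.

Measured compounds:
compound 1 `CCCc1nnc(SCc2ccccc2)n1N1C(=O)c2ccccc2C1=O`: > 200000 nM
compound 2 `CCCc1nnc(SCC(=O)c2ccccc2)n1N1C(=O)c2ccccc2C1=O`: > 200000 nM
compound 3 `COc1cc(-c2nnc(SCc3ccccc3)n2N2C(=O)c3ccccc3C2=O)cc(OC)c1OC`: > 200000 nM

In a functional assay on PC-3M cells (Homo sapiens) for cytotoxicity, read by MTT assay, with a stated time of 48 h (on this read-out higher numbers stand for weaker inhibition and lower numbers for stronger inhibition), compound 1 gives > 200000 nM, which is a limit of the assay and not a number. In this assay compound 2 gives > 200000 nM, likewise a limit. In this assay compound 3 gives > 200000 nM, again a limit. Compound 2 differs from compound 1 by benzoyl in place of phenyl on a saturated chain carbon bound to a sulfur, and the step that the two limits leave unreadable from compound 1 to compound 2. The cores of compound 1 and compound 3 differ by 3,4,5-trimethoxyphenyl in place of propyl on an aromatic carbon, and the step that the two limits leave unreadable from compound 1 to compound 3. All three values sit at the limit of > 200000 nM in this assay, at which 3 of the 3 values shown sit.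

Compound 4 `COc1cc(-c2nnc(SCC(=O)c3ccccc3)n2N2C(=O)c3ccccc3C2=O)cc(OC)c1OC` has not yet been measured in this assay. It differs from compound 3 by benzoyl in place of phenyl on a saturated chain carbon bound to a sulfur, the same change as from compound 1 to compound 2, at the same place. That earlier step could not be read, and the expectation for compound 4 rests only on compound 3 standing at the limit of > 200000 nM in this assay, at which 3 of the 3 values shown sit. For compound 4 in this assay an estimate of 250000 nM is made, expected between 80000 nM and 1000000 nM, which means an expected step that the limit leaves unreadable from compound 3 to compound 4.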

Compound 4, half-maximal inhibitory concentration: > 200000 nM
Compound 4: no number, only a limit (the forecaster's own chance of this, stated with the estimate: 80%); the middle value does not contradict the limit.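

In this assay the steps reaching compound 4 from compound 3 and from compound 2 cannot be read, as each of these compounds gives only a limit and not a number: the limit of > 200000 nM in this assay, at which 4 of the 4 values shown sit.

The compounds shown leave open whether benzoyl in place of phenyl or 3,4,5-trimethoxyphenyl in place of propyl changes inhibition at all in this assay.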